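A few compounds are considered here, and "the series" means these few. Any claim that something is new, unique, unknown or untested is made for them only; others in the source may bear on it.

Working notes on the series. Among the measured compounds shown here, in a functional assay on the whole organism with Rattus norvegicus as the target (a higher number here means that more compound is needed for the effect, a lower number that less compound is needed), compound 1 `CCN(CC)C(=O)Cn1c(=N)sc2cc(OC(F)(F)F)ccc21` gives 9 mg/kg and compound 2 `CCSCCn1c(=N)sc2cc(OC(F)(F)F)ccc21` gives 2.2 mg/kg as the lowest of the two numbers so far. Compound 3 `CSCCCn1c(=N)sc2cc(OC(F)(F)F)ccc21` is not yet measured and has the same atoms as compound 2, joined differently: (methylsulfanyl)methyl in place of ethylsulfanyl on a saturated chain carbon, two bonds along the chain from an aromatic nitrogen in the side chain on the shared core. For the measured compounds named here, the only measured step is a 4.1-fold lower number from compound 1 to compound 2 (0.61 log units; beyond the scatter) and lies beyond the scatter, yet it exchanges diethylcarbamoyl for (ethylsulfanyl)methyl, a different kind of change, so it bears only loosely and sets no size for this one. Going by the values given here, no measured pair tests this kind of rearrangement. The expected change is a 1.3-fold higher number from compound 2 to compound 3 (0.10 log units; within the scatter) and stays within the scatter, with its direction uncertain. For compound 3 the estimate is 2.8 mg/kg with an expected range from 1.1 mg/kg to 7 mg/kg in this series.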

Compound 3, dose for half-maximal effect: 4.2 mg/kg
Beside the measured number, compound 3's estimate is 1.5-fold (0.18 log units) below it, within the range that was stated.
By their numbers in this assay, from the lowest: compounds 2 and 3 (each within the scatter of the next); then compound 1.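

Exchanging ethylsulfanyl for (methylsulfanyl)methyl on a saturated chain carbon, two bonds along the chain from an aromatic nitrogen, gives a 1.9-fold higher number from compound 2 to compound 3 (0.28 log units; within the scatter) in this assay and so does not separate the two arrangements of the same atoms: at this position the sulfur can stand at either place in the chain without a step beyond the scatter. Against diethylcarbamoyl, the second sulfur-bearing chain also gives a step beyond the scatter, with a 2.1-fold lower number from compound 1 to compound 3 (0.33 log units; beyond the scatter) as the reading for 2-(methylsulfanyl)ethyl in that place. Nothing available explains these numbers.

On these data alone, whether the sulfur itself matters stays open, since an ether oxygen in its place would test that. A longer chain or a terminal amine on the same core would show how much else this position accepts.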